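A few compounds are considered here, and "the series" means these few. Any claim that something is new, unique, unknown or untested is made for them only; others in the source may bear on it.

Measured so far in a functional assay on NCI-H460 cells (Homo sapiens) for inhibition, read by sulforhodamine B assay, with a stated time of 48 h; on this read-out higher numbers stand for weaker inhibition of growth and lower numbers for stronger inhibition of growth:
- Compound 1 `CCOC(=O)c1nn(-c2ccc(Cl)cc2)c(-c2ccc(Br)cc2)c1CNC(C)(C)C`: > 511000 nM; > 476000 nM (2 entries), limits only
- Compound 2 `CC(C)(C)NCc1c(C(=O)O)nn(-c2ccccc2)c1-c1ccc(Br)cc1`: > 585000 nM, a limit
- Compound 3 `CC(C)(C)NCc1c(C(=O)O)nn(-c2ccc(Cl)cc2)c1-c1ccc(Cl)cc1`: > 599000 nM, a limit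

Compound 3 has no exact number, since its > 599000 nM is a limit of the assay. Compounds 1 and 2 likewise have limits only, so none of the three can be ranked. Compound 4 `CC(C)(C)NCc1c(C(=O)O)nn(-c2ccc(Cl)cc2)c1-c1ccc(Br)cc1` has bromo in place of chloro on an aromatic carbon, para to a large group: bromo in place of chloro on an aromatic carbon. Among the measured compounds shown here, no measured pair gives a size for this change. The expectation rests on compound 2, which also carries a 4-bromophenyl and gives only a limit, > 585000 nM. In this assay no step beyond the scatter is expected, and another limit is likely. The estimated step, an at least 1.1-fold lower number from compound 3 to compound 4 (0.04 log units; that floor lies within the scatter), lies within the usual scatter. For compound 4 the estimated value is 540000 nM, with an expected range from 400000 nM to 620000 nM.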

Compound 4, concentration for 50% growth inhibition: > 542000 nM
Compound 4 gave a limit, no number; the forecaster's own chance of this, stated with the estimate: 90%; middle value at least 1.0-fold (0.00 log units) away from the limit.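

Compound 4, like compound 2 and compound 3, gives only a limit, so neither step to compound 4 can be read. The compounds shown leave open whether bromo or chloro on the aromatic ring changes growth inhibition at all.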